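Mirror-image pair and a form without drawn configuration

A few compounds are considered here, and "the series" means these few. Any claim that something is new, unique, unknown or untested is made for them only; others in the source may bear on it.

Measured so far in a physicochemical assay for solubility, in phosphate buffer, measured as kinetic solubility, with a stated time of 1 h, at pH 7.4; a higher number here means a more soluble compound, a lower number a less soluble compound:
Compound 1 `Oc1cccc(-c2nccc([C@@]34CCOC[C@@H]3C4)n2)c1`: 123 ug/mL
Compound 2 `Oc1cccc(-c2nccc([C@]34CCOC[C@H]3C4)n2)c1`: 141 ug/mL

Compound 2, at 141 ug/mL, stands level with compound 1 within the scatter. Going by the values given here, the one measured step, a 1.1-fold higher number from compound 1 to compound 2 (0.06 log units; within the scatter), inverts all stereocentres. Compound 3 `Oc1cccc(-c2nccc(C34CCOCC3C4)n2)c1` keeps the same atoms and bonds: the two compounds have the same atoms and bonds; at least one stereo element is drawn with a configuration in one of them and without one in the other: 2 of 2 stereo elements differ; a stereocentre at a saturated ring carbon is drawn R in compound 2 and without a configuration in compound 3; a stereocentre at a saturated ring carbon is drawn S in compound 2 and without a configuration in compound 3. Among the compounds with values here, only that mirror-image step bears on this change, and it stayed within the scatter, so no step beyond the scatter is expected in this assay, in either direction. The expected change is a 1.1-fold lower number from compound 2 to compound 3 (0.04 log units; within the scatter). Compound 3 is estimated at 130 ug/mL, within an expected range of 75 ug/mL to 220 ug/mL.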

Compound 3, solubility: 102 ug/mL
Estimate against measurement, compound 3: 1.3-fold (0.11 log units) above; low and high end bracket the measured number.
By their numbers in this assay, from the lowest: compounds 3, 1 and 2 (each within the scatter of the next).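

In this assay, the form without drawn configuration stands level with both mirror images, with a 1.4-fold lower number from compound 2 to compound 3 (0.14 log units; within the scatter) and a 1.2-fold lower number from compound 1 to compound 3 (0.08 log units; within the scatter). At these two stereocentres, therefore, none of the three drawn forms separates from the others beyond the scatter.

All three compounds share the same atoms and bonds, so they say nothing about how this assay responds to a change of group. From the compounds shown here alone, an amine or a carboxylic acid in place of the hydroxyl remains open, as does whether the configuration would stay equally silent with such a group.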